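The compounds below may be only part of what the source reports. "The series", "measured", "known", "first", "only" and "open" are said of these compounds alone.

Working notes on the series. The shared core is that of compound 1 `C/C(=N\Nc1nc(-c2ccccc2)cs1)c1sc(C)nc1C`. In a toxicity assay on MCF7 cells (Homo sapiens) for cytotoxicity, read by MTT assay (on this read-out higher numbers stand for weaker inhibition of growth and lower numbers for stronger inhibition of growth), compound 1 gives > 100 ug/mL, which is a limit of the assay rather than a number. Compound 2 `C/C(=N\Nc1nc(-c2ccc(Br)cc2)cs1)c1sc(C)nc1C` carries bromo in place of hydrogen on an aromatic carbon. In this assay compound 2 gives > 100 ug/mL, likewise a limit of the assay. The step that the two limits leave unreadable from compound 1 to compound 2 therefore cannot be sized, since (the limit of > 100 ug/mL in this assay, at which 2 of the 2 values shown sit). Compound 3 `C/C(=N\Nc1nc(-c2ccc(C)cc2)cs1)c1sc(C)nc1C` is not yet measured; it differs from compound 2 by methyl in place of bromo on an aromatic carbon. Among the measured compounds shown here, no measured step bears on this change, and no numbered value stands anywhere, so the two limits are the only guide. Compound 3 is expected to sit at the same limit, with an estimated value of 130 ug/mL and a range from 40 ug/mL to 400 ug/mL. The step that the limit leaves unreadable from compound 2 to compound 3 is accordingly expected to stay within the scatter.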

Compound 3, concentration for 50% growth inhibition: > 100 ug/mL
Compound 3: only a limit was reported (the forecaster's own chance of this, stated with the estimate: 80%); the middle value is on the limit's open side.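

Among the compounds shown here, no step among compound 1, compound 2 and compound 3 can be read, because all three sit at the same limit: the limit of > 100 ug/mL in this assay, at which 3 of the 3 values shown sit. The compounds shown leave open how far these three differ in this assay, and whether any change to the shared core gives a numbered value.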